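The source may report more compounds than this note shows. Statements on the series, on what has been measured and on what is new or still open speak of the compounds shown alone.

Of the compounds shown here, three have been measured so far. Compound 1, `O=C(Nc1ccccc1)C1CCN(Cc2ccccc2)CC1`, gives 48.1 nM in an assay on membranes from liver for displacement of a labelled ligand from Sigma non-opioid intracellular receptor 1 (Rattus norvegicus), read by scintillation counting; a lower number here means a stronger inhibitor, a higher number a weaker inhibitor. Compound 2, `Cc1cccc(CN(C)CCCCn2c(=O)oc3ccccc32)c1`, gives 102 nM in this assay. Compound 3, `COc1ccc(CN(C)C(C)CCn2c(=O)oc3ccccc32)cc1`, gives 21 nM in this assay. Among these three numbers compound 3 has the lowest: compound 1 lies closest to it, with a number beyond the scatter of repeat measurements, and compound 2 lies furthest, also beyond that scatter. On what has been measured, compound 3 is therefore the strongest inhibitor of the set.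

The next compound, compound 4, is `COc1ccc(CN(C)CCCn2c(=O)oc3ccccc32)cc1`. It differs from compound 3 in one place: hydrogen in place of methyl on a saturated chain carbon bound to an amine nitrogen and a saturated chain carbon. For the measured compounds named here, no pair of compounds with a single change of this kind has been measured together, so the size of this step rests on judgment rather than on a measured comparison. The chain of compound 4 most resembles that of compound 2, whose number in this assay is the highest of the three, but compound 2 also carries a different group on its benzyl ring, so the two changes cannot be separated. A small loss of potency is expected, with the step from compound 3 to compound 4 estimated at a 1.9-fold higher number from compound 3 to compound 4 (0.28 log units; within the scatter). Compound 4 is expected to give about 40 nM, within a range of 15 nM to 120 nM.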

Compound 4, inhibition constant: 83 nM
For compound 4 the middle estimate is 2.1-fold (0.32 log units) below the measured one; the measured number falls inside the stated range.
By their numbers in this assay, from the lowest: compound 3; then compounds 1, 4 and 2 (each within the scatter of the next, the first and the last beyond it).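

For the compounds shown here, replacing the methyl with hydrogen on a saturated chain carbon bound to an amine nitrogen and a saturated chain carbon gives a 4.0-fold higher number from compound 3 to compound 4 (0.60 log units; beyond the scatter) in this assay, and this is the first measured pair here that differs in one place only. Going by these compounds alone, the step lies beyond the scatter of repeat measurements, so this one carbon of the chain is a place where a small change can be read: with the rest of the molecule held the same, the compound carrying the methyl has the lower number, something the earlier compounds, which differ from one another in several places, could not show. The data in hand offer nothing that accounts for this step.

Still open, as far as these compounds go, is whether a larger group on this carbon, such as ethyl or a cyclopropyl ring, would lower the number further or raise it again. From the compounds shown here alone, it is also open whether the methyl would bring a step of similar size with another group on the benzyl ring, such as chlorine in place of the methoxy group.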